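Salicylanilide series: effect of removing the ring trifluoromethyl

A few compounds are considered here, and "the series" means these few. Any claim that something is new, unique, unknown or untested is made for them only; others in the source may bear on it.

Measured compounds in a functional assay on KG-1 cells (Homo sapiens) for cytotoxicity, read by luminescence and CellTiter-Glo, with a stated time of 3 days; a higher number here means a weaker inhibitor, a lower number a stronger inhibitor:
compound 1 `N#Cc1ccc(NC(=O)c2ccc(C(F)(F)F)cc2O)cc1`: 1440 nM
compound 2 `O=C(Nc1cccc(C(F)(F)F)c1)c1cc(F)ccc1O`: 1010 nM
compound 3 `O=C(Nc1cc(C(F)(F)F)cc(C(F)(F)F)c1)c1ccc(Cl)cc1O`: 620 nM

Compound 1 gives the highest number of the three. Its gap to compound 2 lies within the scatter, so the two cannot be ranked against each other; its gap to compound 3 lies beyond the scatter, with compound 3 the stronger of that pair.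

Compound 4 `N#Cc1ccc(NC(=O)c2ccccc2O)cc1` differs from compound 1 in one place: hydrogen in place of trifluoromethyl on an aromatic carbon. The trifluoromethyl leaves and a hydrogen atom enters, on an aromatic carbon of the six-membered aromatic ring of carbon only, meta to the hydroxy group and para to a large group. Going by the values given here, no measured pair in this set shows this change, so its size is unknown here; compounds 2 and 3 carry a halogen at the corresponding place rather than hydrogen.

For compound 4 in this assay a weaker result than compound 1 is expected, a step estimated at a 2.2-fold higher number from compound 1 to compound 4 (0.35 log units; beyond the scatter). The estimate for compound 4 is 3200 nM, within 1200 nM to 8500 nM.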

Compound 4, half-maximal inhibitory concentration: 5370 nM
The estimate for compound 4 lay 1.7-fold (0.22 log units) below the measured number; measured number inside the range.
By their numbers in this assay, from the lowest: compounds 3, 2 and 1 (each within the scatter of the next, the first and the last beyond it); then compound 4.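

In this assay, going by these compounds alone, compounds 1 and 4 form the first pair that differs in one place, and they give this change a size: a 3.7-fold higher number from compound 1 to compound 4 (0.57 log units; beyond the scatter) when hydrogen replaces trifluoromethyl on the aromatic carbon meta to the hydroxy group and para to a large group. The step lies beyond the scatter, so in the core of compound 1 the trifluoromethyl at this position contributes measurably to the stronger result, which compounds 2 and 3 could not show. No supporting measurement bears on the reason for this step.

Still open, on these data alone, is whether trifluoromethyl is specifically required here, or whether a methyl or methoxy group on the same carbon would serve equally well. As far as these compounds go, it is also open whether the step persists when an amine replaces the nitrile.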